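The source may hold more compounds than are shown below. What is called first, only, known or untested is meant among the compounds shown, and "the series" means these compounds.

In an ADME assay on KB cells (Homo sapiens) for cytotoxicity, read by MTT assay, with a stated time of 72 h (on this read-out lower numbers stand for stronger inhibition and higher numbers for weaker inhibition), compound 1 `COc1ccc(C2=C(c3cc(OC)c(OC)c(OC)c3)C(=O)C(OC(C)=O)C2)cc1OC(C)C` gives > 100 ug/mL, which is a limit of the assay and not a number. Compound 2 `COc1ccc(C2=C(c3cc(OC)c(OC)c(OC)c3)C(=O)CC2O[SiH2]C(C)(C)C)cc1` gives > 100 ug/mL, again a limit and not a number. Compound 3 `COCOc1cc(C2=C(c3cc(OC)c(OC)c(OC)c3)C(=O)CC2O[SiH2]C(C)(C)C)ccc1OC` differs from compound 2 in one place: methoxymethoxy in place of hydrogen on an aromatic carbon, with methoxymethoxy in place of hydrogen on an aromatic carbon. Within the data shown here, no measured step is available as a guide, so no change beyond the usual scatter is expected, and the assay will probably report a limit again. The expected change is a number no higher from compound 2 to compound 3 (the limit leaves the size open). For compound 3 the estimated value is 100 ug/mL, with an expected range of 40 ug/mL to 200 ug/mL.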

Compound 3, half-maximal inhibitory concentration: 33 ug/mL
Estimate against measurement, compound 3: 3.0-fold (0.48 log units) above, and the stated range ends above it.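

On this aromatic carbon, ortho to a methoxy group, methoxymethoxy gives an at least 3.0-fold lower number from compound 2 to compound 3 (0.48 log units; beyond the scatter) in this assay, so a substituent here can bring the read-out within the measurable range. Compound 3 therefore gives later changes a real number to be compared with. Only a minimum size can be read for this step, because compound 2 stands at a limit: the limit of > 100 ug/mL in this assay, at which 2 of the 3 values shown sit.

Going by these compounds, it remains open whether methoxymethoxy itself matters or whether a hydroxyl, an amine or a longer ether chain at this carbon would serve equally well.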